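The source may report more compounds than this note shows. Statements on the series, on what has been measured and on what is new or still open speak of the compounds shown alone.

Compound 1 `CCOc1cc(OC)c(Br)cc1C(C)=O`: 37900000 nM
Compound 2 `CCCCCCOc1cc(OC)c(Br)cc1C(C)=O`: 34000000 nM
Compound 3 `CCCCCCCCOc1cc(OC)c(Br)cc1C(C)=O`: 30900000 nM

In a functional assay, with stated times of 30 s and 6 min, in the presence of a further agent that is not named here (on this read-out higher numbers stand for weaker inhibition and lower numbers for stronger inhibition), compound 1 stands level with the other two compounds, since all three values lie within the scatter of one another. Lengthening the chain on the oxygen gives a 1.1-fold lower number from compound 1 to compound 2 (0.05 log units; within the scatter) and a 1.2-fold lower number from compound 1 to compound 3 (0.09 log units; within the scatter), and the remaining pair shows a 1.1-fold lower number from compound 2 to compound 3 (0.04 log units; within the scatter).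

Compound 4 `CCOc1cc(OC)ccc1C(C)=O` is the next to be measured, and its change lies elsewhere on the core of compound 1: hydrogen in place of bromo on an aromatic carbon. For the measured compounds named here, none of the measured steps touches the bromo, so the data offer no direct guide to this replacement. They bear on it only indirectly, showing that in this assay these compounds have so far stayed close together, as with a 1.2-fold lower number from compound 1 to compound 3 (0.09 log units; within the scatter). No step beyond the scatter is therefore expected, though the uncertainty is wide. The expected step is a 1.1-fold higher number from compound 1 to compound 4 (0.04 log units; within the scatter). For compound 4 the estimated value is 42000000 nM, with an expected range from 15000000 nM to 110000000 nM.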

Compound 4, half-maximal inhibitory concentration: 6600000 nM
Compound 4: middle estimate off by 6.4-fold (0.80 log units), on the high side, and the stated range ends above it.
By their numbers in this assay, from the lowest: compound 4; then compounds 3, 2 and 1 (each within the scatter of the next).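

In this assay, the aromatic carbon ortho to a methoxy group and para to an ethoxy group proves sensitive to change in a way the oxygen chain did not: hydrogen in place of bromo gives a 5.7-fold lower number from compound 1 to compound 4 (0.76 log units; beyond the scatter), a modest step but beyond the scatter. For the compounds shown here, every earlier step, made by lengthening the chain, stayed within the scatter, so this is the first change in the set that clearly moves the number. As lower numbers stand for stronger inhibition here, the bromo is not required for inhibition on this core, and the compound without it inhibits more strongly. No measurement available here accounts for this step. As far as these compounds go, it remains open whether a chloro, a methyl or an amine at this carbon would behave like hydrogen or like bromo, and whether a longer chain on the oxygen would still make no clear difference without the bromo.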